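The source may hold more compounds than are shown below. What is called first, only, known or untested is meant among the compounds shown, and "the series" means these compounds.

Measured so far:
- compound 1, `N#Cc1ccc(-c2cnc(N)c(-c3ccc(N)nc3)n2)cc1`: > 90%
- compound 2, `Nc1ccc(-c2cnc(N)c(-c3ccc(N)nc3)n2)cn1`: > 90%
- compound 3, `Nc1ncc(-c2ccc(C(=O)N3CC[C@H](O)C3)cc2)nc1-c1ccc(C(F)(F)F)cc1`: > 90%

In an ADME assay on microsomes from liver (Mus musculus) for metabolic stability, read by LC-MS, using NADPH, with a stated time of 30 min, tested at 0.1 uM, in the presence of a further agent that is not named here (on this read-out lower numbers stand for a less stable compound and higher numbers for a more stable compound), compound 1 gives > 90%, which is a limit of the assay rather than a number. Compound 2 reaches > 90%, likewise a limit. Compound 3 stands at > 90% in this assay, again a limit and not a number. The three values therefore cannot be ordered among themselves, as the limit of > 90% in this assay, at which 3 of the 3 values shown sit, shows; no difference between any two of them can be read from the data.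

Compound 4, `Nc1ncc(-c2ccc(C(=O)N3CCC(O)C3)cc2)nc1-c1ccc(C(F)(F)F)cc1`, has not yet been tested. Compared with compound 3, the change is the two compounds have the same atoms and bonds; at least one stereo element is drawn with a configuration in one of them and without one in the other: 1 of 1 stereo elements differ; a stereocentre at a saturated ring carbon is drawn S in compound 3 and without a configuration in compound 4. Among the measured compounds shown here, no step between two measured compounds is known in this assay, so nothing measured speaks to the size of such a change. Given the shared atoms and bonds, the step that the limit leaves unreadable from compound 3 to compound 4 is expected to be none beyond the scatter. Compound 4 is accordingly estimated at 93%, within a range from 85% to 100%, most likely reported again as a limit.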

Compound 4, percent of the compound remaining: > 90%
Compound 4: only a limit was reported; the forecaster's own chance of this, stated with the estimate: 85%; the middle value lies beyond the limit too.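

Among the compounds shown here, no step from compound 3 to compound 4 can be read, nor between any other two compounds, because of one shared feature: the limit of > 90% in this assay, at which 4 of the 4 values shown sit. The compounds shown leave open whether the stereocentre drawn S in compound 3 matters at all in this assay.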